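The source may report more compounds than this note shows. Statements on the series, on what has been measured and on what is new or still open speak of the compounds shown alone.

Measured in a functional assay on WM 266-4 cells (Homo sapiens) for antiproliferative activity, read by MTT assay, with a stated time of 48 h; on this read-out lower numbers stand for stronger inhibition and higher numbers for weaker inhibition:
- compound 1 `Cc1ccc(-c2cc(NC(=O)c3ccc(Br)nc3)n[nH]2)cc1`: 6780 nM
- compound 2 `Cc1ccc(-c2cc(NC(=O)c3ccc(Cl)nc3)n[nH]2)cc1`: 5720 nM
- compound 3 `O=C(Nc1cc(-c2ccc(Br)cc2)[nH]n1)c1ccc(Br)nc1`: 8560 nM

The three values sit close together. The change chloro in place of bromo on an aromatic carbon gave a 1.2-fold lower number from compound 1 to compound 2 (0.07 log units; within the scatter). The two cores differ by bromo in place of methyl on an aromatic carbon, and that change gave a 1.3-fold higher number from compound 1 to compound 3 (0.10 log units; within the scatter). Among the measured compounds shown here, compound 4 `O=C(Nc1cc(-c2ccc(Br)cc2)[nH]n1)c1ccc(Cl)nc1` is not yet measured; it differs from compound 3 by chloro in place of bromo on an aromatic carbon, the same change as the one from compound 1 to compound 2, at a place described in identical words.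

The expectation for compound 4 is a 1.2-fold lower number from compound 3 to compound 4 (0.08 log units; within the scatter), resting on compound 1 to compound 2 having given a 1.2-fold lower number from compound 1 to compound 2 (0.07 log units; within the scatter), a step within the scatter. Compound 4 is therefore estimated at 7200 nM in this assay, between 4000 nM and 13000 nM.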

Compound 4, half-maximal inhibitory concentration: 7470 nM
For compound 4 the middle estimate is 1.0-fold (0.02 log units) below the measured one; low and high end bracket the measured number.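

In this assay, chloro in place of bromo gives a 1.1-fold lower number from compound 3 to compound 4 (0.06 log units; within the scatter), matching the earlier step on the other core: the same change on two cores in this assay, a 1.2-fold lower number (0.07 log units; within the scatter) from compound 1 to compound 2 and a 1.1-fold lower number (0.06 log units; within the scatter) from compound 3 to compound 4, 1.0-fold (0.01 log units) apart, within the scatter of two such steps

Bromo in place of methyl gives a 1.3-fold higher number from compound 2 to compound 4 (0.12 log units; within the scatter), which likewise matches its earlier step: the same change on two cores in this assay, a 1.3-fold higher number (0.10 log units; within the scatter) from compound 1 to compound 3 and a 1.3-fold higher number (0.12 log units; within the scatter) from compound 2 to compound 4, 1.0-fold (0.01 log units) apart, within the scatter of two such steps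

Among the compounds shown here, all of these steps lie within the scatter, so the agreement shows only that neither change separated the numbers on these two cores; it does not show that a real effect of either change carries over, and it says nothing about other cores.

Still open, as far as these compounds go, is whether an amine or a methoxy group in place of the chloro, or a carboxylic acid in place of the methyl of compound 1, would give a step beyond the scatter.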